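Swapping a Methoxyphenyl for a Difluorophenyl on the Carbonyl

The compounds below may be only part of what the source reports. "The series", "measured", "known", "first", "only" and "open" are said of these compounds alone.

Among the measured compounds shown here, compound 2 `COc1ccc(C(=O)/C=C/c2cc(-c3cc(OC)c(OC)c(OC)c3)n[nH]2)cc1` gives 1490 nM in a functional assay on SNB-75 cells (Homo sapiens) for inhibition, read by sulforhodamine B assay, with a stated time of 48 h (on this read-out higher numbers stand for weaker inhibition of growth and lower numbers for stronger inhibition of growth), the lower of the two numbers so far; compound 1 `COc1cc(-c2cc(/C=C/C(=O)c3ccc(Cl)c(Cl)c3)[nH]n2)cc(OC)c1OC` gives 8700 nM. For the measured compounds named here, the step of a 5.8-fold lower number from compound 1 to compound 2 (0.77 log units; beyond the scatter) is the only measured change that bears on the next move. Compound 3 `COc1cc(-c2cc(/C=C/C(=O)c3ccc(F)c(F)c3)[nH]n2)cc(OC)c1OC` carries 3,4-difluorophenyl in place of 4-methoxyphenyl on a carbonyl carbon. This runs back in the direction of compound 1, replacing 4-methoxyphenyl with a related 3,4-difluorophenyl, so a higher number is expected for compound 3 in this assay, though its exact size is uncertain. Compound 3 is therefore estimated at 4500 nM with a range of 1500 nM to 13000 nM. That corresponds to an expected step of a 3.0-fold higher number from compound 2 to compound 3 (0.48 log units; beyond the scatter).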

Compound 3, concentration for 50% growth inhibition: 2900 nM
Compound 3: middle estimate off by 1.6-fold (0.19 log units), on the high side; measured number inside the range.
By their numbers in this assay, from the lowest: compounds 2 and 3 (each within the scatter of the next); then compound 1.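

In this assay, 3,4-difluorophenyl and 4-methoxyphenyl on the carbonyl carbon cannot be told apart, with a 1.9-fold higher number from compound 2 to compound 3 (0.29 log units; within the scatter) showing that this position tolerates more than one kind of group. The halogens do separate here, with a 3.0-fold lower number from compound 1 to compound 3 (0.48 log units; beyond the scatter) when 3,4-difluorophenyl replaces 3,4-dichlorophenyl. Nothing available explains either step. Going by these compounds, it remains open how an amine or a carboxylic acid would read on this carbonyl carbon. Also open, on these data alone, is whether a single fluorine would read like 3,4-difluorophenyl.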